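Aryl swap at the saturated ring carbon: compound 3 to compound 4

The compounds below may be only part of what the source reports. "The series", "measured", "known", "first", "only" and "open" are said of these compounds alone.

Of the compounds shown here, three of the shared core have been measured in a functional assay on Ehrlich cells (Mus musculus) for cytotoxicity, read by trypan blue exclusion, with a stated time of 2 h, tested at 25 ug/mL; a lower number here means a weaker effect, a higher number a stronger effect of the compound at the concentration tested. Compound 1 `COc1ccc(C2C(C#N)=C(N)N(c3ccc(S(N)(=O)=O)cc3)C3=C2CCCC3)cc1` gives 90%. Compound 2 `N#CC1=C(N)N(c2ccc(S(N)(=O)=O)cc2)C2=C(CCCC2)C1c1ccccc1Cl` gives 0%. Compound 3 `N#CC1=C(N)N(c2ccc(S(N)(=O)=O)cc2)C2=C(CCCC2)C1c1ccc(Cl)c(Cl)c1` gives 40%, the second highest of the three numbers. The steps show that the group on the saturated ring carbon governs the read-out: a number 90 percentage points lower from compound 1 to compound 2 (beyond the scatter), a number 50 percentage points lower from compound 1 to compound 3 (beyond the scatter) and a number 40 percentage points higher from compound 2 to compound 3 (beyond the scatter).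

Compound 4 `Cc1ccc(C2C(C#N)=C(N)N(c3ccc(S(N)(=O)=O)cc3)C3=C2CCCC3)o1` is not yet measured. Relative to compound 3 the change is 5-methylfuran-2-yl in place of 3,4-dichlorophenyl on a saturated ring carbon. Among the measured compounds shown here, no measured step exchanges a six-membered carbon ring for a five-membered ring with a hetero atom at this position, so only the size of the earlier aryl-to-aryl steps offers guidance; all three lay beyond the scatter and were large. A change beyond the scatter in this assay is therefore expected for compound 4, direction open, estimated as a number 15 percentage points higher from compound 3 to compound 4 (beyond the scatter). The estimate for compound 4 in this assay is 55%, within a range of 10% to 90%.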

Compound 4, a percentage reported as activity, at one concentration (the size of the read-out at that concentration, not a potency): 10%
Beside the measured number, compound 4's estimate is 45 percentage points above it; low and high end bracket the measured number.
By their numbers in this assay, from the lowest: compounds 2 and 4 (each within the scatter of the next); then compound 3; then compound 1.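

Placing 5-methylfuran-2-yl on the saturated ring carbon gives, in this assay, a number 30 percentage points lower from compound 3 to compound 4 (beyond the scatter) and a number 80 percentage points lower from compound 1 to compound 4 (beyond the scatter), so this five-membered aromatic ring with 1 hetero atom does not keep the read-out of either compound. Against the 2-chlorophenyl group the step is a number 10 percentage points higher from compound 2 to compound 4 (within the scatter), so groups differing in ring size and hetero atom can give values that lie within the scatter of each other. A high read-out is therefore not shared by every aromatic ring at this position: compound 1 gives 90%. Among the four compounds, compound 1 alone stands beyond the scatter of all the others.

No available data explain these differences. The compounds shown leave open whether the ring or its methyl group sets the value of compound 4, a question that furan-2-yl and thiophen-2-yl at the same carbon could address.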